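Lengthening the Aminoalkyl Ether Chain of Compound 1

A few compounds are considered here, and "the series" means these few. Any claim that something is new, unique, unknown or untested is made for them only; others in the source may bear on it.

compound 1 `CCN(CC)CCCOc1cc(O)c2c(=O)cc(-c3ccccc3)oc2c1OC` — 1830 nM
compound 2 `CCN(CC)CCCOc1c(O)cc(O)c2c(=O)cc(-c3ccccc3)oc12` — > 100000 nM (a limit of the assay)
compound 3 `COc1c(O)cc(O)c2c(=O)cc(-c3cccc(F)c3)oc12` — "not determined" (no result reported)

Among the measured compounds shown here, in a functional assay on A549 cells (Homo sapiens) for cytotoxicity, read by MTT assay, with a stated time of 48 h (a lower number here means a stronger inhibitor, a higher number a weaker inhibitor), compound 1 gives 1830 nM, the only plain number among the three compounds measured. Compound 2 is reported only at the limit of > 100000 nM in this assay, at which 1 of the 3 values shown sits, which is a limit of the assay and not a number. For compound 3 this assay gives "not determined" (no result reported), so no result stands beside it. For the measured compounds named here, compound 1 therefore stands alone as the one compound with a measured value, and no pair of measured compounds differs in a single place, so no measured step is available.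

Compound 4 `CCN(CC)CCCCOc1cc(O)c2c(=O)cc(-c3ccccc3)oc2c1OC` differs from compound 1 by (diethylamino)methyl in place of diethylamino on a saturated chain carbon, three bonds along the chain from an oxygen on an aromatic ring. The diethylamino end of the chain stays the same and the ether oxygen on the aromatic ring stays the same; only the saturated chain between them grows by one carbon. Going by the values given here, with no measured step of this kind to lean on, the change is expected to move the number little, if at all, beyond the scatter, in either direction. The estimated step from compound 1 to compound 4 is a 1.1-fold higher number from compound 1 to compound 4 (0.04 log units; within the scatter). Compound 4 is thus expected to give 2000 nM, with a range from 700 nM to 6000 nM.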

Compound 4, half-maximal inhibitory concentration: 1000 nM
For compound 4 the middle estimate is 2.0-fold (0.30 log units) above the measured one; the measured number falls inside the stated range.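

Among the compounds shown here, compound 1 and compound 4 form the first measured pair that differs in one place, so the aminoalkyl ether chain now has a readable step: in this assay the change from 3-(diethylamino)propyl to 4-(diethylamino)butyl is a 1.8-fold lower number from compound 1 to compound 4 (0.26 log units; within the scatter) and gives no sign of a real difference between the two. At this place, on a saturated chain carbon, three bonds along the chain from an oxygen on an aromatic ring, the longer chain is therefore compatible with cytotoxicity in the low range seen for compound 1, with the diethylamino end and the ether oxygen unchanged. Nothing measured here accounts for this result.

A single step within the scatter cannot show how the number responds to chain length in general, so a shorter 2-(diethylamino)ethyl chain or a longer 5-(diethylamino)pentyl chain could still behave differently. The compounds shown also leave open whether a cyclic amine such as piperidine or morpholine could take the place of the diethylamino end on either chain.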